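A Fluoro for a Methoxy on a Shared Core

A few compounds are considered here, and "the series" means these few. Any claim that something is new, unique, unknown or untested is made for them only; others in the source may bear on it.

Of the compounds shown here, three built on one shared core have been tested in an ADME assay on HEK-293T cells (Homo sapiens) for cytotoxicity, read by MTT assay, with a stated time of 48 h, in the absence of a further agent; a higher number here means a weaker inhibitor, a lower number a stronger inhibitor. Within the data shown here, compound 1 `COc1ccc2[nH]cc(-c3nc(C(=O)Nc4cc(OC)c(OC)c(OC)c4)cs3)c2c1` carries a methoxy on the fused ring system of that core; in this assay compound 1 gives 8600 nM, the only number recorded. Compound 2 `O=C(Nc1ccccc1)c1csc(-c2cn(Cc3ccc(Cl)cc3)c3ccccc23)n1` reaches only a limit in this assay, > 100000 nM. Compound 3 `O=C(NCc1ccccc1)c1csc(-c2c[nH]c3ccccc23)n1` likewise returns a limit, > 100000 nM. Compound 1 therefore stands alone as the member with a measured value, set against (the limit of > 100000 nM in this assay, at which 2 of the 3 values shown sit).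

Compound 4 `COc1cc(NC(=O)c2csc(-c3c[nH]c4ccc(F)cc34)n2)cc(OC)c1OC` is still to be measured. It differs from compound 1 in one place: fluoro in place of methoxy on an aromatic carbon. The amide side and the remainder of the shared core are unchanged. Among the measured compounds shown here, no step between two measured compounds differing in a single place is available, so the size of this change can only be judged from the structures. A small step is expected, one that stays within the usual scatter of this assay rather than a clear shift in either direction, and the expected step of a 1.2-fold higher number from compound 1 to compound 4 (0.07 log units; within the scatter) reflects that. Compound 4 is estimated at 10000 nM, with a range from 3000 nM to 40000 nM.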

Compound 4, half-maximal inhibitory concentration: > 100000 nM
Compound 4 gave a limit, no number; the forecaster's own chance of this, stated with the estimate: 15%; middle value at least 10-fold (1.00 log units) from the limit.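

In this assay, among these compounds, the exchange of methoxy for fluoro on this aromatic carbon gives the first comparison of two compounds on the shared core that differ in one place, and the step is large: an at least 11-fold higher number from compound 1 to compound 4 (1.06 log units; beyond the scatter). It shows that this position, meta to a fused ring and para to a fused ring, is not indifferent to the group it carries, something compound 1, compound 2 and compound 3 could not show on their own, as no two of them differ in one place only. The result for compound 4 is a limit and not a number, so the full size of the step stays unknown, and compound 1 remains the only compound here with a measured value: the limit of > 100000 nM in this assay, at which 3 of the 4 values shown sit.

The compounds shown do not separate the loss of methoxy from the arrival of fluoro, since this position is seen with only these two groups, and a bare hydrogen, a hydroxyl, a chloro or an amine there would be needed to tell the two apart. Going by these compounds, whether a longer alkoxy chain at this position would keep a number in this assay also remains open.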